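The compounds below may be only part of what the source reports. "The series", "measured", "known", "first", "only" and "open" are said of these compounds alone.

Compound 1 `CCc1ccccc1OC(C)C1=NCCN1` gives 100 nM in a functional assay on CHO cells for agonist activity at Alpha-2C adrenergic receptor (Homo sapiens); a higher number here means that more compound is needed for the effect, a lower number that less compound is needed.
Compound 2 `C=C(C)c1ccccc1OC(C)C1=NCCN1` gives 115 nM in this assay.
Compound 3 `COc1ccccc1OC(C)C1=NCCN1` gives 9770 nM in this assay.

Compound 3 stands at the highest number of the three measured compounds, meaning it needs the most compound to reach the half-maximal effect. The two steps leading to it are both large: a 98-fold higher number from compound 1 to compound 3 (1.99 log units; beyond the scatter) and an 85-fold higher number from compound 2 to compound 3 (1.93 log units; beyond the scatter). Between the other two, a 1.2-fold higher number from compound 1 to compound 2 (0.06 log units; within the scatter), so compound 1 and compound 2 cannot be told apart.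

Compound 4 `CC(Oc1ccccc1S(C)(=O)=O)C1=NCCN1` differs from compound 3 in one place: methylsulfonyl in place of methoxy on an aromatic carbon. Among the compounds with values here, no measured step swaps methoxy for methylsulfonyl, so there is no direct guide. What the measured steps do show is that putting methoxy at this aromatic carbon, in place of ethyl or 1-methylethenyl, raised the number strongly in both cases. Methylsulfonyl resembles neither of those two groups, so there is nothing to suggest a return toward the numbers of compound 1 or compound 2. The expectation for compound 4 is therefore a number near that of compound 3 or somewhat higher, with wide uncertainty: a 1.5-fold higher number from compound 3 to compound 4 (0.19 log units; within the scatter). Compound 4 is estimated at 15000 nM, with a range from 3000 nM to 60000 nM.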

Compound 4, half-maximal effective concentration: 316 nM
Compound 4: the middle estimate sits 47-fold (1.68 log units) above what was measured; the whole stated range lies above it.
By their numbers in this assay, from the lowest: compounds 1 and 2 (each within the scatter of the next); then compound 4; then compound 3.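

Methylsulfonyl in place of methoxy on this aromatic carbon gives a 31-fold lower number from compound 3 to compound 4 (1.49 log units; beyond the scatter), so the large rise seen with methoxy is not something every oxygen-bearing group brings to this position. The recovery is not complete, though: methylsulfonyl in place of ethyl gives a 3.2-fold higher number from compound 1 to compound 4 (0.50 log units; beyond the scatter), and methylsulfonyl in place of 1-methylethenyl gives a 2.7-fold higher number from compound 2 to compound 4 (0.44 log units; beyond the scatter), both modest steps that still lie beyond the scatter, which makes methoxy the outlier among the four groups at this position in this assay. Nothing available on these compounds explains why methylsulfonyl and methoxy behave so differently here.

Going by these compounds, it remains open whether the high number is particular to methoxy or would also appear with other groups on this carbon, such as a hydroxyl, a fluorine or an amine. On these data alone, it is also open whether a close relative of methylsulfonyl, such as ethylsulfonyl, methylsulfinyl or a sulfonamide, would close the remaining modest gap to the ethyl and 1-methylethenyl compounds or widen it.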